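The compounds below may be only part of what the source reports. "The series", "measured", "known", "first", "only" and "open" are said of these compounds alone.

Three compounds have been measured in a functional assay on HepG2 cells (Homo sapiens) for cytotoxicity, read by MTT assay, with a stated time of 72 h; on this read-out higher numbers stand for weaker inhibition of growth and lower numbers for stronger inhibition of growth:

compound 1 `O=C(/N=C(/NC(=O)c1cccs1)[Se]Cc1ccccc1)c1cccs1`: 34700 nM
compound 2 `CS/C(=N\C(=O)c1cccs1)NC(=O)c1cccs1`: > 100000 nM, which is a limit of the assay and not a number
compound 3 `CS/C(=N\C(=O)c1cnc2ccccc2c1)NC(=O)c1cnc2ccccc2c1`: 57600 nM

The value of compound 2 is the limit of > 100000 nM in this assay, at which 1 of the 3 values shown sits. The change from compound 2 to compound 1 is a group of 8 heavy atoms (7 carbon, 1 selenium; one six-membered aromatic ring of carbon only) in place of a group of 2 heavy atoms (1 carbon, 1 sulfur; no ring), on a carbon with a double bond to nitrogen, and it brought an at least 2.8-fold lower number from compound 2 to compound 1 (0.45 log units; beyond the scatter). Compound 3 and compound 1 lie within the usual scatter of each other. The difference between the core of compound 2 and the core of compound 3 is not broken down here.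

Compound 4 `O=C(/N=C(/NC(=O)c1cnc2ccccc2c1)[Se]Cc1ccccc1)c1cnc2ccccc2c1` is not yet measured. Within the data shown here, it differs from compound 3 by a group of 8 heavy atoms (7 carbon, 1 selenium; one six-membered aromatic ring of carbon only) in place of a group of 2 heavy atoms (1 carbon, 1 sulfur; no ring), on a carbon with a double bond to nitrogen, the same change at the same place as the one that links compound 2 and compound 1. Because the measured step was an at least 2.8-fold lower number from compound 2 to compound 1 (0.45 log units; beyond the scatter), a step of a 2.9-fold lower number from compound 3 to compound 4 (0.46 log units; beyond the scatter) is expected in this assay. Compound 4 is therefore estimated at 20000 nM, likely between 7000 nM and 60000 nM.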

Compound 4, concentration for 50% growth inhibition: 8540 nM
Compound 4: middle estimate off by 2.3-fold (0.37 log units), on the high side; measured number inside the range.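

In this assay, replacing methylsulfanyl with the group of 8 heavy atoms that holds selenium and a six-membered aromatic ring gave a 6.7-fold lower number from compound 3 to compound 4 (0.83 log units; beyond the scatter). The number fell on both cores shown, so the direction of the change carried from one core to the other: the same change on two cores in this assay, an at least 2.8-fold lower number (0.45 log units; beyond the scatter) from compound 2 to compound 1 and a 6.7-fold lower number (0.83 log units; beyond the scatter) from compound 3 to compound 4; the limit leaves it open whether they differ The value of compound 2, > 100000 nM, is a limit of the assay and not a number, so the size of the step on that core stays unknown and no claim can be made that the change is larger on either core.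

Which part of the entering group goes with the lower number, the selenium or the aromatic ring, remains open. Also open, on these data alone, is how a benzylsulfanyl group or a plain alkyl chain on selenium would behave at this place, and whether the change would carry to a third core.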